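Series notes: saturated oxygen ring group in place of chlorophenyl

A few compounds are considered here, and "the series" means these few. Any claim that something is new, unique, unknown or untested is made for them only; others in the source may bear on it.

Three compounds of the series have numbers in an ADME assay (liver) for metabolic stability, with Liver microsome (Homo sapiens) as the target, using microsomes; on this read-out higher numbers stand for a longer-lived compound and lower numbers for a shorter-lived compound. Compound 3 `Cc1ccc(-c2nc(C)c([C@H](OC(C)(C)C)C(=O)O)c(-c3ccc(Cl)cc3)c2C)cc1C` gives 1.28 h and stands highest of the three. Its nearest neighbour is compound 1 `Cc1cc(-c2nc(C)c([C@H](OC(C)(C)C)C(=O)O)c(-c3ccc4c(c3)CCCO4)c2C)ccc1Cl`, which gives 0.717 h, a gap within the scatter; furthest is compound 2 `Cc1nc(-c2ccccc2)c(C)c(-c2ccc3c(c2)CCCO3)c1[C@H](OC(C)(C)C)C(=O)O`, which gives 0.533 h, a gap beyond the scatter. For the measured compounds named here, the only measured step between two compounds that differ in one place is a 1.3-fold lower number from compound 1 to compound 2 (0.13 log units; within the scatter), which is within the scatter.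

Compound 4 `Cc1ccc(-c2nc(C)c([C@H](OC(C)(C)C)C(=O)O)c(-c3ccc4c(c3)CCCO4)c2C)cc1C` is not yet measured in this assay. It differs from compound 3 in one place: a group of 10 heavy atoms (9 carbon, 1 oxygen; one six-membered non-aromatic ring with 1 hetero atom, one six-membered aromatic ring of carbon only) in place of a group of 7 heavy atoms (6 carbon, 1 chlorine; one six-membered aromatic ring of carbon only), on an aromatic carbon. Going by the values given here, no measured step covers this exchange, since no pair among compounds 1 to 3 isolates it. Compounds 1 and 2 both carry the entering group and both lie under compound 3, but each differs from compound 4 elsewhere as well, so they give only a rough guide. On that guide a modest downward step is expected, a 1.6-fold lower number from compound 3 to compound 4 (0.20 log units; within the scatter), within the scatter rather than beyond it. The estimate for compound 4 in this assay is 0.8 h, with a range from 0.4 h to 1.6 h.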

Compound 4, half-life: 0.567 h
Compound 4: the middle estimate sits 1.4-fold (0.15 log units) above what was measured; the measured number falls inside the stated range.
By their numbers in this assay, from the lowest: compounds 2, 4, 1 and 3 (each within the scatter of the next, the first and the last beyond it).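

In this assay, the exchange of 4-chlorophenyl for the saturated oxygen ring group, on the aromatic carbon opposite the ring nitrogen, can now be read on its own (a 2.3-fold lower number from compound 3 to compound 4 (0.35 log units; beyond the scatter)), and this step lies beyond the scatter, though it remains a single pair. With the oxygen ring group held in place, the exchanges at the site of the 3,4-dimethylphenyl group stay within the scatter (a 1.1-fold higher number from compound 2 to compound 4 (0.03 log units; within the scatter); a 1.3-fold lower number from compound 1 to compound 4 (0.10 log units; within the scatter)), so among compounds 1, 2 and 4 the change from phenyl or 4-chloro-3-methylphenyl to 3,4-dimethylphenyl gives no readable difference. Nothing shown accounts for the size or direction of the step from 4-chlorophenyl to the oxygen ring group.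

As far as these compounds go, it remains open whether that step would be the same size with phenyl or 4-chloro-3-methylphenyl at the other site, since only the 3,4-dimethylphenyl pair isolates it. Also open, from the compounds shown here alone, is how a methoxy group, an amine or an unsubstituted phenyl group on the same aromatic carbon would compare with 4-chlorophenyl and the oxygen ring group on this read-out.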